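A few compounds are considered here, and "the series" means these few. Any claim that something is new, unique, unknown or untested is made for them only; others in the source may bear on it.

Of the compounds shown here, three of a shared core have been measured in a functional assay on A498 cells (Homo sapiens) for inhibition, read by sulforhodamine B assay, with a stated time of 48 h; on this read-out higher numbers stand for weaker inhibition and lower numbers for stronger inhibition. Compound 1 `COc1cc(-c2nn(-c3cccc(NC(=O)c4cccc(C(F)(F)F)c4)c3)cc2-c2ccncc2)ccc1Cl` gives 690 nM. Compound 2 `COc1cc(-c2nn(-c3cccc(NC(=O)Nc4ccc(Cl)c(Cl)c4)c3)cc2-c2ccncc2)ccc1Cl` gives 1140 nM, and compound 3 `COc1cc(-c2nn(-c3cccc(NC(=O)c4ccc(Cl)c(C(F)(F)F)c4)c3)cc2-c2ccncc2)ccc1Cl` gives 2700 nM. Compound 3 thus has the highest number of the three: the step of a 3.9-fold higher number from compound 1 to compound 3 (0.59 log units; beyond the scatter) and the step of a 2.4-fold higher number from compound 2 to compound 3 (0.37 log units; beyond the scatter) both lie beyond the scatter, while the step of a 1.7-fold higher number from compound 1 to compound 2 (0.22 log units; within the scatter) does not.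

Compound 4 `COc1cc(-c2nn(-c3cccc(NC(=O)Nc4ccc(Cl)c(C(F)(F)F)c4)c3)cc2-c2ccncc2)ccc1Cl` is the next compound to be measured. It differs from compound 3 in one place: (4-chloro-3-(trifluoromethyl)phenyl)amino in place of 4-chloro-3-(trifluoromethyl)phenyl on a carbonyl carbon. Among the compounds with values here, the measured step that bears most directly on this change is the one from compound 1 to compound 2, where the same kind of exchange, from an aryl group to an arylamino group on the carbonyl carbon, was joined to a change in the ring substituents and gave only a modest rise within the scatter. Compound 2, which already carries the arylamino group, also stands between compound 1 and compound 3. Compound 4 is therefore expected to land close to compound 3, with the step of a 1.4-fold lower number from compound 3 to compound 4 (0.13 log units; within the scatter) small and most likely within the scatter, and the estimate for compound 4 in this assay is 2000 nM, with a range from 800 nM to 5000 nM.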

Compound 4, half-maximal inhibitory concentration: 840 nM
Beside the measured number, compound 4's estimate is 2.4-fold (0.38 log units) above it; the measured number falls inside the stated range.
By their numbers in this assay, from the lowest: compounds 1, 4 and 2 (each within the scatter of the next); then compound 3.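

In this assay, within the data shown here, the exchange of 4-chloro-3-(trifluoromethyl)phenyl for (4-chloro-3-(trifluoromethyl)phenyl)amino on the carbonyl carbon gives a 3.2-fold lower number from compound 3 to compound 4 (0.51 log units; beyond the scatter); this reads the exchange on its own, whereas the earlier compounds showed it only joined to a change in the ring substituents. Within the arylamino pair, trifluoromethyl in place of chloro on an aromatic carbon gives only a 1.4-fold lower number from compound 2 to compound 4 (0.13 log units; within the scatter), so that exchange cannot be read as a difference here. The step of a 1.2-fold higher number from compound 1 to compound 4 (0.09 log units; within the scatter) also stays small, so the arylamino compound carrying chloro does not show the rise seen with the aryl compound, a 3.9-fold higher number from compound 1 to compound 3 (0.59 log units; beyond the scatter).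

The data shown offer no evidence on why the number moves with this exchange. As far as these compounds go, how a methylene or an ether oxygen in place of the amino nitrogen would read remains open, as does a carboxylic acid or an amine on the aryl ring.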